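Carbamate aryl-to-sulfonyl swap on the chromanol series

The source may report more compounds than this note shows. Statements on the series, on what has been measured and on what is new or still open speak of the compounds shown alone.

Four carbamates on a shared chromanol core with a long unsaturated side chain are considered. Compound 1 `CC(C)=CCC/C(C)=C/CC/C(C)=C/CC[C@]1(C)CCc2c(C)c(OC(=O)NS(=O)(=O)c3ccc(Cl)cc3)c(C)c(C)c2O1` carries a (4-chlorophenyl)sulfonyl group on the carbamate nitrogen, compound 2 `CC(C)=CCC/C(C)=C/CC/C(C)=C/CC[C@]1(C)CCc2c(C)c(OC(=O)Nc3ccccc3)c(C)c(C)c2O1` a phenyl group in the same position, and compound 3 `CC(C)=CCC/C(C)=C/CC/C(C)=C/CC[C@]1(C)CCc2cc(OC(=O)Nc3ccccc3)c(C)c(C)c2O1` keeps the phenyl carbamate on a core lacking one aromatic methyl. Compound 4 `CC(C)=CCC/C(C)=C/CC/C(C)=C/CC[C@]1(C)CCc2cc(OC(=O)NS(=O)(=O)c3ccc(Cl)cc3)c(C)c(C)c2O1` is not yet measured.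

In a functional assay on MDA-MB-231 cells (Homo sapiens) for antiproliferative activity, read by MTT assay, with a stated time of 96 h (a higher number here means a weaker inhibitor, a lower number a stronger inhibitor), compound 1 returns only a limit, > 10000 nM. Compound 2 likewise gives only a limit in this assay, > 10000 nM. Compound 3 also sits at a limit in this assay, > 10000 nM. All three values therefore lie at the same point, (the limit of > 10000 nM in this assay, at which 3 of the 3 values shown sit).

The change from compound 2 to compound 1 is (4-chlorophenyl)sulfonyl in place of phenyl on an amide-type nitrogen, and the step it produced in this assay is a step that the two limits leave unreadable from compound 2 to compound 1. The two cores differ by hydrogen in place of methyl on an aromatic carbon, with a step that the two limits leave unreadable from compound 2 to compound 3. Compound 4 is reached from compound 3 by (4-chlorophenyl)sulfonyl in place of phenyl on an amide-type nitrogen, the same change as from compound 2 to compound 1, and the place is described identically in both cases.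

Given that compound 3 sits at a limit and that the same change from compound 2 to compound 1 left both at the limit, compound 4 is expected to give a step that the limit leaves unreadable from compound 3 to compound 4. This expectation rests on a step that the two limits leave unreadable from compound 2 to compound 1. It also rests on compound 3 giving only a limit, > 10000 nM. The estimate for compound 4 in this assay is 20000 nM, with a range from 8000 nM to 60000 nM, most likely reported again as a limit.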

Compound 4, half-maximal inhibitory concentration: > 10000 nM
Compound 4 gave a limit, no number (the forecaster's own chance of this, stated with the estimate: 85%); the middle value is on the limit's open side.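

In this assay compound 4 returns only a limit, and no step can be read from compound 3 to compound 4 or from compound 1 to compound 4: the limit of > 10000 nM in this assay, at which 4 of the 4 values shown sit.

The compounds shown leave open whether (4-chlorophenyl)sulfonyl in place of phenyl on the amide-type nitrogen, or hydrogen in place of methyl on an aromatic carbon, changes antiproliferative activity at all, as none of the four gives a number.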